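Oxazole Substituent Change Within a Conserved Bicyclic Core

This account rests on a few compounds, and the source may have more. Where it says the series, first, only, none or still open, it means among the compounds named here.

Compound 3 `Cc1nc([C@H](C(=O)N(C)C)N2C(=O)[C@@H](C3Cc4ccccc4C3)NC(=O)[C@H]2CC(C)C)c(C)o1` gives 3.16 nM in an assay on isolated protein for binding affinity to Oxytocin receptor (Homo sapiens) (a lower number here means a stronger inhibitor, a higher number a weaker inhibitor), the highest number among the three measured compounds. Compound 1 `CC(C)C[C@@H]1C(=O)N[C@H](C2Cc3ccccc3C2)C(=O)N1[C@@H](C(=O)NC(C)C)c1ccc(Br)s1` gives 2 nM, within the scatter of compound 3, while compound 2 `Cc1nc([C@H](C(=O)N(C)C)N2C(=O)[C@@H](C3Cc4ccccc4C3)NC(=O)[C@H]2CC(C)C)cs1` gives 0.398 nM. Going by the values given here, the one step that touches the same position, a 7.9-fold higher number from compound 2 to compound 3 (0.90 log units; beyond the scatter), shows that the choice of five-membered aromatic ring at this site shifts the result modestly. Compound 4 `CC(C)C[C@@H]1C(=O)N[C@H](C2Cc3ccccc3C2)C(=O)N1[C@@H](C(=O)N(C)C)c1coc(C2CC2)n1` carries 2-cyclopropyl-1,3-oxazol-4-yl in place of 2,5-dimethyl-1,3-oxazol-4-yl on a saturated chain carbon bound to an amide-type nitrogen in a ring and a carbonyl carbon. Among the compounds with values here, no measured pair isolates the cyclopropyl group, so the expectation rests on the step between compound 2 and compound 3 alone. Compound 4 is therefore expected to improve modestly if at all, an estimated 1.6-fold lower number from compound 3 to compound 4 (0.20 log units; within the scatter). The estimate for compound 4 is 2 nM, with a range from 0.6 nM to 6.3 nM.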

Compound 4, inhibition constant: 0.794 nM
Compound 4: middle estimate off by 2.5-fold (0.40 log units), on the high side, and the stated range covers the measured number.
By their numbers in this assay, from the lowest: compounds 2 and 4 (each within the scatter of the next); then compounds 1 and 3 (each within the scatter of the next).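

In this assay, the 2-cyclopropyl-1,3-oxazol-4-yl group shows that an oxazole at this position can give a number close to that of the thiazole: a 4.0-fold lower number from compound 3 to compound 4 (0.60 log units; beyond the scatter), while a 2.0-fold higher number from compound 2 to compound 4 (0.30 log units; within the scatter). The higher number seen with 2,5-dimethyl-1,3-oxazol-4-yl therefore does not hold for both oxazoles shown. Nothing available explains this difference.

The change alters two ring substituents at once, so the compounds shown leave open how much each contributes. A 2-methyl-1,3-oxazol-4-yl group would separate them.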